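The compounds below may be only part of what the source reports. "The series", "measured", "known", "first", "only" and "open" are said of these compounds alone.

Measured compounds in an ADME assay on A2780 cells (Homo sapiens) for cytotoxicity, read by MTT assay, with a stated time of 72 h; on this read-out higher numbers stand for weaker inhibition of growth and lower numbers for stronger inhibition of growth:
- compound 1 `CCCCNC(=O)C1C(C(=O)O)[C@@H]2CC[C@H]1O2` gives 10000 nM
- compound 2 `CCCCCCCCCCNC(=O)C1C(C(=O)O)[C@@H]2CC[C@H]1O2` gives 10000 nM
- compound 3 `CCOC(=O)c1cn[nH]c1NC(=O)C1C(C(=O)O)[C@@H]2CC[C@H]1O2` gives 10000 nM

All three compounds share one core and differ only in the group attached to the amide nitrogen. On the numbers shown, compound 2 stands level with compound 1 and with compound 3 in this assay. Among the compounds with values here, the one step that is counted, no change at the digits printed from compound 1 to compound 2 (within the scatter), shows that lengthening the chain on the amide nitrogen left the read-out where it was.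

Compound 4 `O=C(O)C1C(C(=O)NCCCc2ccccc2)[C@H]2CC[C@@H]1O2` is not yet measured. It differs from compound 2 in one place: phenyl in place of heptyl on a saturated chain carbon, three bonds along the chain from an amide-type nitrogen. Within the data shown here, the only step that bears on this change is the one from compound 1 to compound 2, which was flat, and compound 3, with a quite different group on the same nitrogen, also sits at the same value. Nothing here points to any direction, so no step beyond the scatter is expected in this assay.

The expected step from compound 2 to compound 4 is no change at the digits printed from compound 2 to compound 4 (within the scatter). Compound 4 is estimated at 10000 nM, within a range from 5000 nM to 20000 nM.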

Compound 4, concentration for 50% growth inhibition: 10000 nM
Beside the measured number, compound 4's estimate shows no gap at the digits printed, and the stated range covers the measured number.
By their numbers in this assay, from the lowest: compounds 1, 2, 3 and 4 (each within the scatter of the next).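

In this assay, the earlier step changed only the length of a saturated chain, whereas compound 4 brings a six-membered aromatic ring of carbon only to this place on the chain. That swap of phenyl for heptyl leaves the read-out flat (no change at the digits printed from compound 2 to compound 4 (within the scatter)), and so does the comparison of phenyl with methyl (no change at the digits printed from compound 1 to compound 4 (within the scatter)). No measurement here accounts for this lack of change.

The compounds shown leave open whether an amine or a hydroxyl group at the end of the chain, or a chlorine on the phenyl ring, would move the read-out. With all four compounds level, they also do not show whether any change to the shared core or its carboxylic acid would do so.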